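Notes on varying the substituent on the core nitrogen

A few compounds are considered here, and "the series" means these few. Any claim that something is new, unique, unknown or untested is made for them only; others in the source may bear on it.

Three compounds share one core and differ only in the group carried on the ring nitrogen that sits beside the carbonyl position of compound 1 `CC(C)=CCn1nc(-c2cccnc2)c2ccccc2c1=O`. In a functional assay (trachea) with Cavia porcellus as the target (a higher number here means a weaker inhibitor, a lower number a stronger inhibitor), compound 1 gives 1380 nM, the lowest of the three numbers measured. Compound 2 `COC(=O)c1ccc(Cn2nc(-c3cccnc3)c3ccccc3c2=O)cc1` gives 5890 nM in this assay, a gap from compound 1 that lies beyond the scatter. Compound 3 `O=c1c2ccccc2c(-c2cccnc2)nn1S(=O)(=O)c1ccccc1` gives 14800 nM in this assay and stands furthest from compound 1, again beyond the scatter. Going by the values given here, the two measured larger groups thus both sit at higher numbers than the small olefinic chain of compound 1, though with only three compounds no general rule can be drawn.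

Compound 4 `O=c1c2ccccc2c(-c2cccnc2)nn1CCSc1ncccn1` has not yet been measured. Compared with compound 1 it carries ((pyrimidin-2-yl)sulfanyl)methyl in place of 2-methylprop-1-en-1-yl on a saturated chain carbon bound to an aromatic nitrogen. The entering group brings an aromatic ring and acceptor atoms where compound 1 has a plain hydrocarbon chain; among the measured compounds, compound 2 and compound 3 show that ring-bearing groups at this position gave higher numbers than compound 1. A moderate rise beyond the scatter is therefore the expected direction for the step of a 2.5-fold higher number from compound 1 to compound 4 (0.40 log units; beyond the scatter). For compound 4 the estimated value in this assay is 3500 nM, with a range from 900 nM to 14000 nM.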

Compound 4, half-maximal inhibitory concentration: 11000 nM
The estimate for compound 4 lay 3.1-fold (0.50 log units) below the measured number; measured number inside the range.
By their numbers in this assay, from the lowest: compound 1; then compounds 2, 4 and 3 (each within the scatter of the next, the first and the last beyond it).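

The ((pyrimidin-2-yl)sulfanyl)methyl group in place of 2-methylprop-1-en-1-yl gives an 8.0-fold higher number from compound 1 to compound 4 (0.90 log units; beyond the scatter) in this assay, so a ring-bearing group reached through a saturated chain also sits well apart from the plain hydrocarbon chain of compound 1. Compound 4 lies within the scatter of both compound 2 and compound 3, so all three ring-bearing groups are now at higher numbers than compound 1, with no shown compound going against this, and compound 1 at 1380 nM remains the only one at the low end. Nothing on hand accounts for the size of this step.

This step brings in the sulfur and the pyrimidine ring together, so the compounds shown do not separate what each contributes, and a simple phenyl ring on the same chain or a thioether carrying only a small alkyl group would be needed to do so. Also open, from the compounds shown here alone, is whether a longer saturated hydrocarbon chain, an amine or a carboxylic acid at the end of the chain would stay near compound 1 or join the higher group.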